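Hydroxyacid oxidase inhibitors: swapping the aryl substituent of compound 2

The source may report more compounds than this note shows. Statements on the series, on what has been measured and on what is new or still open speak of the compounds shown alone.

Measured compounds:
- compound 1 `Cc1csc(-c2cccc(CN(C)c3ccc4[nH]nc(C(=O)O)c4c3)c2)n1`: 650 nM
- compound 2 `Cc1csc(-c2cccc(CNc3ccc4[nH]nc(C(=O)O)c4c3)c2O)n1`: 23 nM
- compound 3 `CN(C)c1noc(-c2cccc(CNc3ccc4[nH]nc(C(=O)O)c4c3)c2Cl)n1`: 180 nM

In an assay on isolated protein for inhibition of 2-Hydroxyacid oxidase 1 (Homo sapiens), with stated times of 30 min and 15 min (a lower number here means a stronger inhibitor, a higher number a weaker inhibitor), compound 2 gives 23 nM, the lowest of the three numbers. Compound 3 is the nearest to it and compound 1 the furthest, both separated from compound 2 by steps beyond the scatter. For the measured compounds named here, no pair among the three differs in a single place, so nothing in the measured set isolates the effect of one group.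

Compound 4 `CN(C)C(=O)c1cccc(CNc2ccc3[nH]nc(C(=O)O)c3c2)c1O` is the next compound to go into this assay. Its structural change from compound 2 is dimethylcarbamoyl in place of 4-methyl-1,3-thiazol-2-yl on an aromatic carbon. The shared core and the hydroxy group stay in place; only the substituent on the phenyl ring is exchanged, an aromatic ring leaving and a non-cyclic group entering.

Nothing measured here shows what happens when the five-membered aromatic ring is removed from this position, so the expected step from compound 2 to compound 4 is set with wide bounds: a modest rise in the number, beyond the scatter but well short of the gap to compound 1, is expected, a 3.5-fold higher number from compound 2 to compound 4 (0.54 log units; beyond the scatter). Compound 4 is therefore estimated at 80 nM in this assay, with a range from 25 nM to 300 nM.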

Compound 4, half-maximal inhibitory concentration: > 30000 nM
Compound 4: no number, only a limit; the forecaster's own chance of this, stated with the estimate: 5%; middle value at least 370-fold (2.57 log units) away from the limit.
By their numbers in this assay, from the lowest: compound 2; then compound 3; then compound 1. At a limit, above all of these: compound 4.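

In this assay compound 4 gives > 30000 nM, which is a limit of the assay and not a number. For the compounds shown here, compounds 2 and 4 form the only pair here that differs in one place: dimethylcarbamoyl replaces 4-methyl-1,3-thiazol-2-yl on an aromatic carbon ortho to a hydroxy group, with the shared core unchanged, and the result is an at least 1300-fold higher number from compound 2 to compound 4 (3.11 log units; beyond the scatter). This position is therefore not indifferent to what it carries, since exchanging the five-membered aromatic ring for this non-cyclic group moves the read-out to the top of the assay's range, and the size of the step is known only as a bound: the limit of > 30000 nM in this assay, at which 1 of the 4 values shown sits.

The compounds shown do not separate the loss of the aromatic ring from the entry of the dimethylcarbamoyl group; a phenyl ring, a pyridine ring, or a simple methyl group at this position would bear on that question. The contribution of the hydroxy group also stays unread, as no pair shown differs at that place alone.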